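The source may hold more compounds than are shown below. What is called first, only, known or untested is meant among the compounds shown, and "the series" means these compounds.

Measured so far in a functional assay on HCT-116 cells (Homo sapiens) for inhibition, read by MTT assay, with a stated time of 72 h; a lower number here means a stronger inhibitor of growth, a higher number a weaker inhibitor of growth:
- compound 1 (`COC1CN(C(=O)/C=C/c2ccncc2-c2ccc(F)cc2)C1`) gives "not determined" (no result reported)
- compound 2 (`CCOC(=O)/C=C/c1ccncc1-c1ccc2ccccc2c1`) gives 910 nM
- compound 3 (`CN1CCN(c2ccc(Nc3cnccc3/C=C/C(N)=O)cc2)CC1`) gives "not determined" (no result reported)

Among the measured compounds shown here, compound 2 holds the only number in this small set, since no result is reported for the other two compounds. Compound 4 (`NC(=O)/C=C/c1ccncc1-c1ccc2ccccc2c1`) has amino in place of ethoxy on a carbonyl carbon, so ethoxycarbonyl becomes carbamoyl. For the measured compounds named here, no step between measured compounds is available to size this change, and the expectation rests on compound 2 alone, at 910 nM in this assay. A modest shift toward weaker inhibition of growth is expected, though a result within the scatter would be no surprise, and the estimated step is a 1.6-fold higher number from compound 2 to compound 4 (0.22 log units; within the scatter) here. For compound 4 the expected value is 1500 nM, with an estimated range from 300 nM to 7000 nM.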

Compound 4, concentration for 50% growth inhibition: 12100 nM
Compound 4: the middle estimate sits 8.1-fold (0.91 log units) below what was measured; the measured number lies above the stated range.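

In this assay, the group on this carbonyl carbon proves to matter for growth inhibition: amino in place of ethoxy gives a 13-fold higher number from compound 2 to compound 4 (1.12 log units; beyond the scatter), a step beyond the scatter. Among the compounds shown here, this is the first sized change in the set, and it shows that with the rest of the structure held constant, ethoxycarbonyl and carbamoyl are not interchangeable here. No evidence at hand accounts for the size of this step.

From the compounds shown here alone, whether a carboxylic acid, a methylamino group or a longer ester chain at this carbon would stand nearer compound 2 or compound 4 remains open. Whether the step would recur on another core is also unresolved.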